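Half-life notes: chloro in place of 4-methoxyphenyl

The compounds below may be only part of what the source reports. "The series", "measured", "known", "first", "only" and "open" are said of these compounds alone.

Measured in a physicochemical assay for metabolic stability, read by HPLC, in phosphate buffer, at pH 7.4, tested at 10 uM; a lower number here means that the compound disappears faster, a higher number that the compound lasts longer:
- compound 1 `O=C(c1ccccc1)c1ccc2c(c1)oc(=O)n2C(=O)NCCCCc1ccccc1`: 1.63 h
- compound 2 `COc1ccc(-c2ccc3c(c2)oc(=O)n3C(=O)NCCCCc2ccccc2)cc1`: 2.2 h

For the measured compounds named here, only two numbers exist so far, and compound 2 at 2.2 h is not separated from the other one: the single measured step is a 1.3-fold higher number from compound 1 to compound 2 (0.13 log units; within the scatter). Next comes compound 3 `O=C(NCCCCc1ccccc1)n1c(=O)oc2cc(Cl)ccc21`, with this change: chloro in place of 4-methoxyphenyl on an aromatic carbon. In words, this is chloro in place of 4-methoxyphenyl on an aromatic carbon. The measured step also exchanges one group for another on an aromatic carbon, and it stays within the scatter. Going by the values given here, no measured compound carries chloro, so the data give no direct reading for that group and no direction. Among the compounds with values here, with only that step to go on, no step beyond the scatter is expected in this assay. The expected step is a 1.1-fold lower number from compound 2 to compound 3 (0.04 log units; within the scatter). The estimated half-life of compound 3 is 2 h (range 1 h to 4 h).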

Compound 3, half-life: 0.967 h
For compound 3 the middle estimate is 2.1-fold (0.32 log units) above the measured one; measured number below the stated range.
By their numbers in this assay, from the lowest: compounds 3, 1 and 2 (each within the scatter of the next, the first and the last beyond it).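

In this assay, for the compounds shown here, this position on an aromatic carbon proves sensitive to the group it carries: chloro in place of 4-methoxyphenyl gives a 2.3-fold lower number from compound 2 to compound 3 (0.36 log units; beyond the scatter), the first step to pass the scatter. Chloro in place of benzoyl gives a 1.7-fold lower number from compound 1 to compound 3 (0.23 log units; within the scatter), so compound 3 is separated from compound 2 but not from compound 1, and the effect of chloro depends on the group used for comparison. No measurement at hand accounts for the step from the 4-methoxyphenyl compound.

Still open, going by these compounds, is whether bromo, an amine or a carboxylic acid at this position would stand with chloro or with 4-methoxyphenyl in this assay. Also open, on these data alone, is how a longer chain in place of the one shared by all three compounds would change the half-life.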